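The source may hold more compounds than are shown below. What is called first, only, known or untested is meant among the compounds shown, and "the series" means these compounds.

Measured in a functional assay on MDA-MB-231 cells (Homo sapiens) for antiproliferative activity, read by MTT assay, with a stated time of 24 h; on this read-out higher numbers stand for weaker inhibition and lower numbers for stronger inhibition:
Compound 1 `COC(=O)c1scc(-c2ccc(NC(=O)c3ccccn3)cc2)c1OC`: 8250 nM
Compound 2 `COC(=O)c1scc(-c2ccc(NC(=O)c3ccc(F)c(Cl)n3)cc2)c1OC`: 10300 nM
Compound 3 `COC(=O)c1scc(-c2ccc(NC(=O)c3cc(I)ccc3F)cc2)c1OC`: 16500 nM

Compound 3, at 16500 nM, lies within the scatter of both other compounds. Compound 4 `COC(=O)c1scc(-c2ccc(NC(=O)c3ccc(OC)nc3)cc2)c1OC` differs from it in one place, with 6-methoxypyridin-3-yl in place of 2-fluoro-5-iodophenyl on a carbonyl carbon. Three measured steps exchange the group at this same place: a 1.2-fold higher number from compound 1 to compound 2 (0.10 log units; within the scatter), a 2.0-fold higher number from compound 1 to compound 3 (0.30 log units; within the scatter) and a 1.6-fold higher number from compound 2 to compound 3 (0.20 log units; within the scatter). Among the compounds with values here, all three stay within the scatter, although no measured compound carries 6-methoxypyridin-3-yl. No step beyond the scatter is therefore expected in this assay. The estimated change is a 1.7-fold lower number from compound 3 to compound 4 (0.22 log units; within the scatter), which is expected to stay within the scatter. Compound 4 is expected at 10000 nM, within an estimated range of 4500 nM to 22000 nM.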

Compound 4, half-maximal inhibitory concentration: 15300 nM
Compound 4: middle estimate off by 1.5-fold (0.18 log units), on the low side, and the stated range covers the measured number.
By their numbers in this assay, from the lowest: compounds 1, 2, 4 and 3 (each within the scatter of the next).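

In this assay, 6-methoxypyridin-3-yl brings hydrogen-bond acceptors and a ring hetero atom where 2-fluoro-5-iodophenyl has neither, yet a 1.1-fold lower number from compound 3 to compound 4 (0.03 log units; within the scatter) and a 1.5-fold higher number from compound 2 to compound 4 (0.17 log units; within the scatter) and a 1.9-fold higher number from compound 1 to compound 4 (0.27 log units; within the scatter) all stay within the scatter. The position on the carbonyl carbon therefore now tolerates a methoxy-bearing ring as well as halogenated and unsubstituted ones, with no exchange among these four compounds going beyond the scatter. Nothing available explains this flatness.

The compounds shown leave open whether any group here can move the number beyond the scatter, such as a ring carrying an amine or a carboxylic acid, or a longer chain.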